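The source may hold more compounds than are shown below. What is called first, only, known or untested is meant among the compounds shown, and "the series" means these compounds.

Of the compounds shown here, three with a shared core have been measured in a functional assay on MCF7 cells (Homo sapiens) for cytotoxicity, read by MTT assay, with a stated time of 96 h; on this read-out lower numbers stand for stronger inhibition and higher numbers for weaker inhibition. Compound 1 (`COc1cc(C(=O)c2cn(-c3ccc(C)cc3)cc2-c2ccc(N)cc2)cc(OC)c1OC`) gives 6 nM, compound 2 (`COc1cc(C(=O)c2cn(-c3ccc(N)cc3)cc2-c2ccccc2F)cc(OC)c1OC`) gives 28 nM, and compound 3 (`COc1cc(C(=O)c2cn(-c3ccc(N)cc3)cc2-c2ccc([N+](=O)[O-])cc2)cc(OC)c1OC`) gives 260 nM, the highest of the three numbers and so the weakest result here. Compound 4 (`COc1cc(C(=O)c2cn(-c3ccc(N)cc3)cc2-c2ccc(N)cc2)cc(OC)c1OC`) has amino in place of nitro on an aromatic carbon. Among the compounds with values here, the one measured step involving this nitro group shows a 9.3-fold higher number from compound 2 to compound 3 (0.97 log units; beyond the scatter), with 4-nitrophenyl entering. Compound 1, which carries 4-aminophenyl, gives 6 nM. A clear fall in the number is therefore expected, an estimated 13-fold lower number from compound 3 to compound 4 (1.11 log units; beyond the scatter). The expected value for compound 4 is 20 nM, with an estimated range from 4 nM to 90 nM.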

Compound 4, half-maximal inhibitory concentration: 15 nM
Compound 4: middle estimate off by 1.3-fold (0.12 log units), on the high side; low and high end bracket the measured number.
By their numbers in this assay, from the lowest: compound 1; then compounds 4 and 2 (each within the scatter of the next); then compound 3.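

Nitro is a poor group at this spot: in this assay, changing it to amino gives a 17-fold lower number from compound 3 to compound 4 (1.24 log units; beyond the scatter) and recovers most of what compound 3 lacks. Replacing 2-fluorophenyl with 4-aminophenyl gives a 1.9-fold lower number from compound 2 to compound 4 (0.27 log units; within the scatter) and so separates neither, whereas amino in place of the methyl of compound 1 gives a 2.5-fold higher number from compound 1 to compound 4 (0.40 log units; beyond the scatter) and shows that this second change counts. No measurement explains these shifts.

On these data alone, whether a hydroxyl or a dimethylamino group could replace the amino group at this spot stays open.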